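Swapping the dihydroxyethyl chain for propyl on compound 1

The source may report more compounds than this note shows. Statements on the series, on what has been measured and on what is new or still open speak of the compounds shown alone.

Measured so far:
- compound 1, `Nc1nc(O)c2c(n1)n(C1OC(CO)[C@@H](O)[C@H]1O)c(=O)n2CC(O)CO`: 136%
- compound 2, `C=CCn1/c(=N\C#N)n([C@H]2OC(CO)[C@@H](O)[C@H]2O)c2cc(N)nc(O)c21`: 85%

In a functional assay on the whole organism (B cells) with Mus musculus as the target (on this read-out lower numbers stand for smaller maximal responses and higher numbers for larger maximal responses), compound 1 gives 136%, the highest of the two numbers shown. In this assay compound 2 gives 85%, a value beyond the usual scatter below compound 1. Among the measured compounds shown here, both share a nucleoside-like core; the two compounds differ in several places at once, so no single structural step between them can be read off.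

Compound 3, `CCCCn1c(=O)n(C2OC(CO)[C@@H](O)[C@H]2O)c2nc(N)nc(O)c21`, has not yet been measured. It differs from compound 1 in one place: propyl in place of 1,2-dihydroxyethyl on a saturated chain carbon bound to an aromatic nitrogen. For the measured compounds named here, no measured pair shows what this particular exchange does.

Because compound 1 gives 136%, a high starting point, compound 3 is expected to land somewhat lower, though the step may not exceed the scatter. The expected step is a number 21 percentage points lower from compound 1 to compound 3 (beyond the scatter). Compound 3 is estimated at 115%, within the range 80% to 150%.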

Compound 3, largest response reached (reported as maximal response), in percent of the reference or control that the assay uses: 86%
For compound 3 the middle estimate is 29 percentage points above the measured one, within the range that was stated.
By their numbers in this assay, from the lowest: compounds 2 and 3 (each within the scatter of the next); then compound 1.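

In this assay, propyl in place of 1,2-dihydroxyethyl on a saturated chain carbon bound to an aromatic nitrogen gives a number 50 percentage points lower from compound 1 to compound 3 (beyond the scatter), so the response depends on what this position carries. Among the compounds shown here, this is the first comparison here in which only one place changes: the chain that leaves has hydrogen-bond donors and acceptors, while the propyl that enters has none, but this single pair cannot show which difference between the two groups matters. No supporting measurement is available to explain the drop.

The compounds shown leave open how the response would change with a hydroxyethyl chain, an aminoethyl chain, a carboxylic acid or a longer chain such as hexyl at this place. They also leave open whether the same exchange would produce a step of similar size on a different core.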